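The source may report more compounds than this note shows. Statements on the series, on what has been measured and on what is new or still open speak of the compounds shown alone.

Working notes on the series. Among the compounds with values here, compound 1 `OC(CCCN1CCN(c2ncc(F)cn2)CC1)C1CCCCC1` is the only member with a number so far: in an assay (Cavia porcellus) for displacement of a labelled ligand from Sigma non-opioid intracellular receptor 1 (Homo sapiens) (a higher number here means a weaker inhibitor, a lower number a stronger inhibitor), compound 1 gives 12 nM. Within the data shown here, compound 2 `Fc1cnc(N2CCN(CCCCC3CCCCC3)CC2)nc1` shares the core of compound 1 but carries hydrogen where compound 1 carries a hydroxyl; in this assay compound 2 has no result reported, so compound 2 stands nowhere yet on the measured scale and no step from compound 1 to compound 2 can be given. Compound 3 `O=C(NC(CCCN1CCN(c2ncc(F)cn2)CC1)C1CCCCC1)c1ccc(F)cc1` is the next member to be run in this assay. The change from compound 2 to compound 3 is ((4-fluorophenyl)carbonyl)amino in place of hydrogen on a saturated chain carbon bound to a saturated chain carbon and a saturated ring carbon. Among the measured compounds shown here, with no measured pair to lean on, the step in this assay expected from this change is modest and, on the evidence of the core shared with compound 1, likely to stay near the potency of compound 1 rather than move far in either direction. For compound 3 the half-maximal inhibitory concentration in this assay is estimated at 20 nM, with a range from 4 nM to 100 nM.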

Compound 3, half-maximal inhibitory concentration: > 2 nM
Compound 3: no number, only a limit; the forecaster's own chance of this, stated with the estimate: 5%; the middle value is on the limit's open side.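

In this assay compound 3 gives > 2 nM, which is a limit and not a number. Within the data shown here, no step from compound 1 to compound 3 can be read from it. The compounds shown leave open whether ((4-fluorophenyl)carbonyl)amino in place of hydroxy changes potency, and in which direction.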